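The compounds below may be only part of what the source reports. "The series", "measured", "known", "first", "only" and "open" are said of these compounds alone.

Measured so far:
compound 1, `C/C(=N/O)c1ccc(OCC(=O)Nc2ccc(C(=O)/C=C/c3ccc(Cl)cc3)cc2)cc1`, 66%
compound 2, `COc1ccc(/C=C/C(=O)c2ccc(NC(=O)COc3ccc(/C(C)=N\O)cc3)cc2)cc1`, 46%
compound 3, `O=C(COCc1c(-c2ccccc2)no[n+]1[O-])Nc1ccc(C(=O)/C=C/c2ccc(Cl)cc2)cc1`, 66%

The three measured compounds were tested in a functional assay on the whole organism (strain albino) for inhibition, with Rattus norvegicus as the target, read by paw edema, with stated times of 30 min and 3 h, at a dose of 100 mg/kg by the oral route; a lower number here means less inhibition, a higher number more inhibition at the dose given (going by the name of the read-out). Compound 1 gives 66% in this assay, and compound 3 gives 66%; these two values agree within the scatter, so no order is read between them. Compound 2 gives 46%, the lowest of the three, and its gap to each of the other two lies beyond the scatter.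

Compound 1 and compound 2 differ in one place: methoxy in place of chloro on an aromatic carbon. This change makes the step of a number 20 percentage points lower from compound 1 to compound 2 (beyond the scatter).

Compound 3 carries a different core from compound 1; the difference between the two cores is not broken down here. Compound 4, `COc1ccc(/C=C/C(=O)c2ccc(NC(=O)COCc3c(-c4ccccc4)no[n+]3[O-])cc2)cc1`, is not yet measured. It relates to compound 3 as compound 2 relates to compound 1: methoxy in place of chloro on an aromatic carbon. The place lines of the two changes agree word for word, so this is the same change made on a second core.

With one precedent only, the step expected from compound 3 to compound 4 is taken from that precedent: a drop of about the same size is estimated, a number 20 percentage points lower from compound 3 to compound 4 (beyond the scatter), because the same change gave a number 20 percentage points lower from compound 1 to compound 2 (beyond the scatter). The expectation that a change carries over from one core to another rests on a single pair, so the range is kept wide. Compound 4 is thus estimated at 46% in this assay, between 32% and 60%.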

Compound 4, a percentage reported as inhibition, in the whole organism at one dose (the size of the read-out at that dose, not a potency): 56%
Compound 4: middle estimate off by 10 percentage points, on the low side; the range from low to high includes it.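

In this assay, going by these compounds alone, methoxy in place of chloro on the aromatic carbon para to a large group gives a number 10 percentage points lower from compound 3 to compound 4 (within the scatter), so on the core of compound 3 this step cannot be told apart from no step, while on the core of compound 1 it gave a number 20 percentage points lower from compound 1 to compound 2 (beyond the scatter). Even so, the two steps cannot be told apart from each other, and the series gives no ground for saying that the two cores respond differently to this change: the same change on two cores in this assay, a number 20 percentage points lower (beyond the scatter) from compound 1 to compound 2 and a number 10 percentage points lower (within the scatter) from compound 3 to compound 4, 10 percentage points apart, within the scatter of two such steps. Within the data shown here, this is consistent with the change carrying over between these two cores, but it does not show that the step has a fixed size, since it rests on only two pairs, each read as inhibition at a single dose rather than as a potency, and neither a shared step nor a dependence on the core is established.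

The compounds shown leave open how other groups at this place would read, such as fluoro, methyl, or a dimethylamino group, and how the ring would read with hydrogen alone there. Also open, as far as these compounds go, is whether the comparison between 4-chlorophenyl and 4-methoxyphenyl would hold on a third core, or at other doses in this assay.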